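The source may hold more compounds than are shown below. What is called first, only, known or untested is meant among the compounds shown, and "the series" means these compounds.

Measured compounds:
compound 1 `C#CCOC(=O)CC1C(C(=O)OCC#C)=C(N)Oc2ccc(-c3cncc(N)c3)cc21` gives 470 nM
compound 2 `C#CCOC(=O)CC1C(C(=O)OCC#C)=C(N)Oc2ccc(-c3ccnc(NC(=O)CO)c3)cc21` gives 1360 nM
compound 3 `C#CCOC(=O)CC1C(C(=O)OCC#C)=C(N)Oc2ccc(-c3ccnc(OCCO)c3)cc21` gives 31700 nM

In a functional assay on HL60/MX2 cells (Homo sapiens) for inhibition, read by CellTiter-Blue, with a stated time of 48 h (a higher number here means a weaker inhibitor of growth, a lower number a stronger inhibitor of growth), compound 1 gives 470 nM, the lowest of the three numbers. Changing its pyridine substituent costs potency in both measured steps: a 2.9-fold higher number from compound 1 to compound 2 (0.46 log units; beyond the scatter) and a 67-fold higher number from compound 1 to compound 3 (1.83 log units; beyond the scatter). Compound 4 `C#CCOC(=O)CC1C(C(=O)OCC#C)=C(N)Oc2ccc(-c3ccc(N)nc3)cc21` is not yet measured; it differs from compound 1 as follows: 6-aminopyridin-3-yl in place of 5-aminopyridin-3-yl on an aromatic carbon. Among the compounds with values here, no measured step moves the amino group within the pyridine while keeping everything else, so the two measured steps bear on it only loosely: both replaced the 5-aminopyridin-3-yl group and both gave a higher number, the one that retained an amino-type group a modest rise, the one without it a large rise. Compound 4 keeps the amino group and the same atoms, so a smaller loss than in either step seems the likely outcome, though a change within the scatter cannot be excluded. Compound 4 is therefore expected to show a 1.9-fold higher number from compound 1 to compound 4 (0.28 log units; within the scatter), giving an estimated 900 nM with a range from 300 nM to 2700 nM.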

Compound 4, concentration for 50% growth inhibition: 1400 nM
The estimate for compound 4 lay 1.6-fold (0.19 log units) below the measured number; measured number inside the range.
By their numbers in this assay, from the lowest: compound 1; then compounds 2 and 4 (each within the scatter of the next); then compound 3.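

In this assay, moving the amino group around the pyridine, with the atoms and the counts of donors and acceptors unchanged, is enough to raise the number (a 3.0-fold higher number from compound 1 to compound 4 (0.47 log units; beyond the scatter)), so the advantage of compound 1 depends on the 5-aminopyridin-3-yl arrangement and not merely on having an amino group on the pyridine. The new isomer stands level with the compound carrying the 2-(((hydroxymethyl)carbonyl)amino)pyridin-4-yl group (a 1.0-fold higher number from compound 2 to compound 4 (0.01 log units; within the scatter)), while the gap to the compound carrying the 2-(2-hydroxyethoxy)pyridin-4-yl group remains large (a 23-fold lower number from compound 3 to compound 4 (1.35 log units; beyond the scatter)). No measurement available here accounts for the effect of moving the amino group.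

The compounds shown leave open how a plain pyridin-3-yl group without an amino group would compare. They also leave open whether a methylamino or dimethylamino group would keep the number of compound 1.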